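The compounds below may be only part of what the source reports. "The series", "measured", "known", "first", "only" and "open" are said of these compounds alone.

Compound 1 `COc1ccc(/C=C/C(=O)c2ccc(OC)c3c2OC(C)(C)C=C3)c(F)c1` and compound 2 `COc1ccc(C(=O)/C=C/c2ccc3ccccc3c2)c2c1C=CC(C)(C)O2` share one core with different aryl groups on the chain. In a functional assay on SK-OV-3 cells (Homo sapiens) for antiproliferative activity, read by MTT assay, with a stated time of 24 h (a lower number here means a stronger inhibitor, a higher number a weaker inhibitor), compound 1 gives 4880 nM, the lower of the two numbers, while compound 2 gives 7650 nM, a gap within the usual scatter, so neither can be called the more potent. Compound 3 `COc1ccc(C(=O)/C=C/c2ccsc2)c2c1C=CC(C)(C)O2` has not been measured in this assay. It differs from compound 1 by thiophen-3-yl in place of 2-fluoro-4-methoxyphenyl on a double-bonded chain carbon bound to a double-bonded chain carbon. Within the data shown here, no measured pair tells what such a change does, so only a step of no more than the scatter, if anything toward a weaker inhibitor, is expected a 1.4-fold higher number from compound 1 to compound 3 (0.16 log units; within the scatter). Compound 3 is therefore estimated at 7000 nM, within 2500 nM to 20000 nM.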

Compound 3, half-maximal inhibitory concentration: > 10000 nM
Compound 3: only a limit was reported; the forecaster's own chance of this, stated with the estimate: 15%; middle value at least 1.4-fold (0.15 log units) away from the limit.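

In this assay compound 3 gives > 10000 nM, which is a limit of the assay and not a number. Thiophen-3-yl in place of 2-fluoro-4-methoxyphenyl on a double-bonded chain carbon bound to a double-bonded chain carbon brings an at least 2.0-fold higher number from compound 1 to compound 3 (0.31 log units; beyond the scatter), so the group at this position can shift the result beyond the scatter. How far the step reaches cannot be read from a limit: the limit of > 10000 nM in this assay, at which 1 of the 3 values shown sits.

The compounds shown leave open whether the fluorine, the methoxy group or the whole six-membered ring matters here. A plain phenyl or a furan-3-yl at this place would help to separate these.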